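Methyl in place of hydrogen: compound 3 to compound 4

The compounds below may be only part of what the source reports. "The series", "measured", "known", "first", "only" and "open" are said of these compounds alone.

Going by the values given here, in a functional assay on C6 cells (Rattus norvegicus) for cytotoxicity, read by MTT assay, with a stated time of 24 h, tested at 100 ug/mL (a lower number here means a stronger effect, a higher number a weaker effect of the compound at the concentration tested), compound 3 `Cc1nnc(SCC(=O)N/N=c2/scc(-c3ccccc3)n2-c2ccccc2)s1` gives 61.8%, the highest of the three numbers so far; compound 2 `Cc1nnc(SCC(=O)N/N=c2/scc(-c3ccc(Cl)cc3)n2-c2ccccc2)s1` gives 34.1% and compound 1 `Cc1ccc(-c2cs/c(=N/NC(=O)CSc3nnnn3-c3ccccc3)n2-c2ccccc2)cc1` gives 28.5%. Compound 4 `Cc1ccc(-c2cs/c(=N/NC(=O)CSc3nnc(C)s3)n2-c2ccccc2)cc1` carries methyl in place of hydrogen on an aromatic carbon, which read one bond further out is phenyl to 4-methylphenyl. Among the compounds with values here, the only measured step at the same place is a number 27.7 percentage points higher from compound 2 to compound 3 (beyond the scatter), a rise well beyond the scatter on loss of the substituent. Within the data shown here, compound 1 carries the same methyl group on a different core and gives the lowest number, though no single-change step links it to compound 4. A fall of comparable size is therefore expected, and compound 4 is estimated at 36% within 22% to 54%, a step of a number 25.8 percentage points lower from compound 3 to compound 4 (beyond the scatter).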

Compound 4, a percentage reported as activity, at one concentration (the size of the read-out at that concentration, not a potency): 31.5%
Compound 4: the middle estimate sits 4.5 percentage points above what was measured, and the stated range covers the measured number.
By their numbers in this assay, from the lowest: compounds 1, 4 and 2 (each within the scatter of the next); then compound 3.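

On this aromatic carbon, methyl gives a number 30.3 percentage points lower from compound 3 to compound 4 (beyond the scatter) in this assay, and methyl in place of chloro gives a number 2.6 percentage points lower from compound 2 to compound 4 (within the scatter), so the two substituents read alike and both differ from hydrogen. With 4-methylphenyl kept, exchanging the group on sulfur gives a number 3 percentage points higher from compound 1 to compound 4 (within the scatter), so 5-methyl-1,3,4-thiadiazol-2-yl and 1-phenyl-1H-tetrazol-5-yl also read alike here. No evidence on the origin of these steps is available.

Open: whether a methoxy group or an amine on this aromatic carbon would read like methyl and chloro or like hydrogen.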